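This account rests on a few compounds, and the source may have more. Where it says the series, first, only, none or still open, it means among the compounds named here.

Compound 1 `COC1=C(C)C(=O)/C(=C(O)/C=C/c2ccc(F)cc2)C(=O)C1(C)C`: 7.2 ug/mL
Compound 2 `COC1=C(C)C(=O)/C(=C(O)/C=C/c2ccccc2C)C(=O)C1(C)C`: 9 ug/mL

In a functional assay on PC-3 cells (Homo sapiens) for cytotoxicity (a lower number here means that less compound is needed, a higher number that more compound is needed for the effect), compound 2 gives 9 ug/mL and cannot be told apart from compound 1, which gives 7.2 ug/mL. Compound 3 `CCc1ccc(/C=C/C(O)=C2/C(=O)C(C)=C(OC)C(C)(C)C2=O)cc1` keeps the shared core and changes one group: 4-ethylphenyl in place of 2-methylphenyl on a double-bonded chain carbon bound to a double-bonded chain carbon. Going by the values given here, the only measured step at this place is a 1.3-fold higher number from compound 1 to compound 2 (0.10 log units; within the scatter), where 2-methylphenyl replaced 4-fluorophenyl. With that single step as a guide, no change beyond the scatter is expected in this assay, in either direction. The expected step is a 1.1-fold lower number from compound 2 to compound 3 (0.05 log units; within the scatter). Compound 3 is estimated at 8 ug/mL, with an expected range of 4 ug/mL to 16 ug/mL.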

Compound 3, concentration for half-maximal effect: 15.1 ug/mL
Beside the measured number, compound 3's estimate is 1.9-fold (0.28 log units) below it; the range from low to high includes it.
By their numbers in this assay, from the lowest: compounds 1, 2 and 3 (each within the scatter of the next, the first and the last beyond it).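

At this position, 4-ethylphenyl in place of 2-methylphenyl stays within the scatter in this assay (a 1.7-fold higher number from compound 2 to compound 3 (0.22 log units; within the scatter)). Ethyl in place of fluoro on an aromatic carbon gives the first step beyond the scatter, though a modest one (a 2.1-fold higher number from compound 1 to compound 3 (0.32 log units; beyond the scatter)). No evidence bears on why this step occurs. The compounds shown leave open how a longer chain, such as butyl, would read on that aromatic carbon. They also leave open whether an amine or a carboxylic acid there would give a lower or higher number.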